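A few compounds are considered here, and "the series" means these few. Any claim that something is new, unique, unknown or untested is made for them only; others in the source may bear on it.

Measured compounds:
- compound 1, `COc1ccccc1/C=C(/SCc1ccc(Cl)c(Cl)c1)C(=O)c1ccc(Cl)cc1`, in a functional assay on DU-145 cells (Homo sapiens) for inhibition, read by trypan blue exclusion, with a stated time of 96 h (a lower number here means a stronger inhibitor of growth, a higher number a weaker inhibitor of growth), gives 10000 nM
- compound 2, `CCOc1ccc(/C=C(/Sc2ccc(C)cc2)C(=O)c2ccc(Cl)cc2)cc1OC`, in this assay gives 25000 nM
- compound 3, `COc1ccccc1/C=C(/Sc1ccc(C)cc1)C(=O)c1ccc(Cl)cc1`, in this assay gives 25000 nM

All three share a sulfur-bearing double-bonded chain that carries a carbonyl group, and they differ in what hangs on the sulfur and in the ring at the other end of the chain. Compound 3 and compound 2 have the same group on the sulfur but different rings at the chain end; the difference between the two cores is not broken down here. Their values in this assay sit level with each other, within the scatter of the measurement.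

Between compound 3 and compound 1 one change is made: 3,4-dichlorobenzyl in place of 4-methylphenyl on a sulfur. This step gives a 2.5-fold lower number from compound 3 to compound 1 (0.40 log units; beyond the scatter), a modest gain that is nevertheless beyond the scatter.

Compound 4, `CCOc1ccc(/C=C(/SCc2ccc(Cl)c(Cl)c2)C(=O)c2ccc(Cl)cc2)cc1OC`, has not yet been measured. It stands to compound 2 exactly as compound 1 stands to compound 3: 3,4-dichlorobenzyl in place of 4-methylphenyl on a sulfur. The surroundings of the sulfur read the same in both cases, so this is the same change made on the core of compound 2 instead of the core of compound 3.

For the measured compounds named here, since the only example of this change is the step from compound 3 to compound 1, the expectation rests on that alone, and compound 4 is expected to show about a 2.5-fold lower number from compound 2 to compound 4 (0.40 log units; beyond the scatter) relative to compound 2. With one example the step could be larger or smaller, so the range is kept wide. In this assay compound 4 is therefore estimated at 10000 nM, between 4000 nM and 25000 nM.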

Compound 4, concentration for 50% growth inhibition: 25000 nM
Compound 4: middle estimate off by 2.5-fold (0.40 log units), on the low side, within the range that was stated.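

In this assay, putting 3,4-dichlorobenzyl in place of 4-methylphenyl on the sulfur of the core of compound 2 gives no change at the digits printed from compound 2 to compound 4 (within the scatter), and setting this beside the earlier step gives the following comparison: the same change on two cores in this assay, a 2.5-fold lower number (0.40 log units; beyond the scatter) from compound 3 to compound 1 and no change at the digits printed (within the scatter) from compound 2 to compound 4, 2.5-fold (0.40 log units) apart, within the scatter of two such steps. The gap between the two steps is therefore no larger than repeated measurements of this kind could produce, so these data do not show that the change behaves differently on the two cores. For the compounds shown here, they do not show that it reliably carries over either, since only one of the two steps lies beyond the scatter, and two pairs of compounds are too few to support a rule for the whole series.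

On these data alone, this swap also alters two things at once, replacing a phenyl with a benzyl and a methyl with two chlorines, so it remains open how much each part contributes, a question that a plain benzyl or a 4-methylbenzyl on the sulfur could help to separate on both cores. Also open, as far as these compounds go, is how the number would respond to quite different groups on the sulfur, such as a longer chain or a benzyl bearing an amine or a carboxylic acid.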